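Methoxy on the benzoyl ring of the thiadiazine series

This account rests on a few compounds, and the source may have more. Where it says the series, first, only, none or still open, it means among the compounds named here.

For the measured compounds named here, compound 3 `COc1cc(-c2nnc3n2NC(c2ccco2)C(C(=O)c2ccccc2)S3)cc(OC)c1OC` is the one member of this set with a number in a functional assay on MCF7 cells (Homo sapiens) for cytotoxicity, read by MTT assay, with a stated time of 48 h; a lower number here means a stronger inhibitor, a higher number a weaker inhibitor: compound 3 gives 39800 nM. Compound 1 `COc1cc(C(=O)C2Sc3nnc(-c4cc(OC)c(OC)c(OC)c4)n3NC2c2ccco2)cc(OC)c1OC` sits at a limit of the assay, > 100000 nM, not a number. Compound 2 `COc1cc(-c2nnc3n2NC(c2ccco2)C(C(=O)C2CC2)S3)cc(OC)c1OC` likewise sits at a limit, > 100000 nM. The step from a step that the two limits leave unreadable from compound 1 to compound 2 therefore cannot be read. The step of an at least 2.5-fold lower number from compound 1 to compound 3 (0.40 log units; beyond the scatter) and the step of an at least 2.5-fold lower number from compound 2 to compound 3 (0.40 log units; beyond the scatter) both run toward the unsubstituted phenyl on the carbonyl carbon, and both hit (the limit of > 100000 nM in this assay, at which 2 of the 3 values shown sit).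

Compound 4 `COc1ccc(C(=O)C2Sc3nnc(-c4cc(OC)c(OC)c(OC)c4)n3NC2c2ccco2)cc1` differs from compound 3 by methoxy in place of hydrogen on an aromatic carbon. The nearest measured step is an at least 2.5-fold lower number from compound 1 to compound 3 (0.40 log units; beyond the scatter), where removing three methoxy groups from that aryl ketone lowered the number; putting one methoxy back is expected to move part of the way in the opposite direction, so a rise beyond the scatter, a 1.8-fold higher number from compound 3 to compound 4 (0.25 log units; within the scatter), is expected. Compound 4 is estimated at 70000 nM, within 30000 nM to 160000 nM, with a real chance that only a limit is reported.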

Compound 4, half-maximal inhibitory concentration: > 100000 nM
Compound 4: only a limit was reported; the forecaster's own chance of this, stated with the estimate: 35%; middle value at least 1.4-fold (0.15 log units) from the limit.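

In this assay, for the compounds shown here, methoxy in place of hydrogen on the benzoyl ring gives an at least 2.5-fold higher number from compound 3 to compound 4 (0.40 log units; beyond the scatter), so a single methoxy, para to a large group, is enough to take the series back to a limit, which the earlier compounds showed only for the full 3,4,5-trimethoxyphenyl. The steps among compound 1, compound 2 and compound 4 cannot be read, since each joins two limits, so the three cannot be ordered. The unsubstituted phenyl of compound 3 remains the only readable point, and the size of the methoxy step is open on one side: the limit of > 100000 nM in this assay, at which 3 of the 4 values shown sit.

From the compounds shown here alone, it remains open whether the loss is specific to methoxy or follows any group on that aromatic carbon, such as fluoro, hydroxy or an amine. Going by these compounds, it is also open whether any group on that ring gives a lower number than compound 3 does.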